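This account rests on a few compounds, and the source may have more. Where it says the series, first, only, none or still open, it means among the compounds named here.

In a functional assay on PC-3 cells (Homo sapiens), read by MTT assay, with a stated time of 48 h (a lower number here means a stronger inhibitor, a higher number a weaker inhibitor), three amides sharing one core have been measured. Compound 1 (`CCOC(=O)CN(C)C(=O)c1ccc(C(CC)(CC)c2ccc(OCC(O)C(C)(C)C)c(C)c2)n1CC`) gives 25500 nM, compound 2 (`CCn1c(C(=O)N(C)CCC#N)ccc1C(CC)(CC)c1ccc(OCC(O)C(C)(C)C)c(C)c1`) gives 1700 nM, and compound 3 (`C=CCN(C)C(=O)c1ccc(C(CC)(CC)c2ccc(OCC(O)C(C)(C)C)c(C)c2)n1CC`) gives 25900 nM. Compound 3 therefore sits level with compound 1, and both are far weaker than compound 2.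

The next compound, compound 4 (`CC[C@@H](C)[C@H](NC(=O)c1ccc(C(CC)(CC)c2ccc(OCC(O)C(C)(C)C)c(C)c2)n1CC)C(=O)O`), changes the amide again: (1-carboxy-2-methylbutyl)amino in place of allyl(methyl)amino on a carbonyl carbon. In short, (1-carboxy-2-methylbutyl)amino stands in place of allyl(methyl)amino on a carbonyl carbon.

The measured steps also alter the amide substituent. The step of a 1.0-fold higher number from compound 1 to compound 3 (0.01 log units; within the scatter) shows no real change, whereas a 15-fold lower number from compound 1 to compound 2 (1.18 log units; beyond the scatter) and a 15-fold higher number from compound 2 to compound 3 (1.18 log units; beyond the scatter) are both large. Going by the values given here, the gain is seen only in compound 2, the one compound with a nitrile. Among the compounds with values here, compound 4 has no nitrile, and no measured compound carries a free carboxy group, so the guidance is weak.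

The expected step is a 1.7-fold lower number from compound 3 to compound 4 (0.24 log units; within the scatter), leaning slightly towards a lower number but not clearly beyond the scatter. The estimated value for compound 4 is 15000 nM, with an expected range of 3000 nM to 60000 nM.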

Compound 4, half-maximal inhibitory concentration: 1900 nM
Compound 4: middle estimate off by 7.9-fold (0.90 log units), on the high side, and the stated range ends above it.
By their numbers in this assay, from the lowest: compounds 2 and 4 (each within the scatter of the next); then compounds 1 and 3 (each within the scatter of the next).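

In this assay, (1-carboxy-2-methylbutyl)amino in place of allyl(methyl)amino on the carbonyl carbon gives a large step (a 14-fold lower number from compound 3 to compound 4 (1.13 log units; beyond the scatter)), and replacing the ester-bearing amine group of compound 1 gives one of similar size (a 13-fold lower number from compound 1 to compound 4 (1.13 log units; beyond the scatter)), so a nitrile is not required for a low number at this position. Compound 4 and compound 2 stay within the scatter of each other (a 1.1-fold higher number from compound 2 to compound 4 (0.05 log units; within the scatter)), even though their amine groups are quite different and only compound 4 has a carboxy group and two defined stereocentres. No measurement here explains why these two different groups give such similar numbers.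

Still open, on these data alone, is which part of the new group matters: the carboxy group, the branched chain, the stereocentres or the amide hydrogen. A primary amide in place of the carboxy group, or a shorter unbranched chain, would help to separate these parts.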